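Swapping the propyl amine for a methylpyrazole

This account rests on a few compounds, and the source may have more. Where it says the series, first, only, none or still open, it means among the compounds named here.

Compound 1 `CCCNc1ccnc(Nc2ccc(NC(=O)Nc3ccc(Cl)c(C(F)(F)F)c3)cc2)n1`: 4610 nM
Compound 2 `O=C(Nc1ccc(Nc2nccc(Nc3cccc(Cl)c3)n2)cc1)Nc1ccc(Cl)c(C(F)(F)F)c1`: 10400 nM

In a functional assay on MCF7 cells (Homo sapiens) for antiproliferative activity, read by MTT assay, with a stated time of 72 h (on this read-out lower numbers stand for stronger inhibition and higher numbers for weaker inhibition), compound 1 gives the lowest of the two numbers, with compound 2 nearest at 10400 nM. Compound 3 `Cn1cc(Nc2ccnc(Nc3ccc(NC(=O)Nc4ccc(Cl)c(C(F)(F)F)c4)cc3)n2)cn1` is not yet measured; it differs from compound 1 by 1-methyl-1H-pyrazol-4-yl in place of propyl on a nitrogen on an aromatic ring. Going by the values given here, the one measured step that bears on this change, a 2.3-fold higher number from compound 1 to compound 2 (0.35 log units; beyond the scatter), was modest and went toward weaker inhibition. Compound 3 is therefore expected to show a similar small step, a 1.2-fold higher number from compound 1 to compound 3 (0.08 log units; within the scatter), or none beyond the scatter. Compound 3 is estimated at 5500 nM, within a range of 1800 nM to 17000 nM.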

Compound 3, half-maximal inhibitory concentration: 9770 nM
Compound 3: middle estimate off by 1.8-fold (0.25 log units), on the low side, within the range that was stated.
By their numbers in this assay, from the lowest: compound 1; then compounds 3 and 2 (each within the scatter of the next).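

In this assay, 1-methyl-1H-pyrazol-4-yl in place of propyl on this nitrogen gives a 2.1-fold higher number from compound 1 to compound 3 (0.33 log units; beyond the scatter), so a second aromatic ring, this one five-membered with 2 hetero atoms, also goes toward weaker inhibition. The two aromatic groups cannot be told apart, with a 1.1-fold lower number from compound 2 to compound 3 (0.03 log units; within the scatter), so the hetero atoms and the chlorine make no difference that this read-out can resolve. Nothing available explains this result.

The compounds shown leave open whether a longer alkyl chain or a cyclopropyl group on this nitrogen would match propyl or go beyond it.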